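Replacing the aryl group on compound 3's amino nitrogen

This account rests on a few compounds, and the source may have more. Where it says the series, first, only, none or still open, it means among the compounds named here.

In a functional assay on HeLa cells (Homo sapiens) for antiproliferative activity, read by spectrophotometry, with a stated time of 2 days (a higher number here means a weaker inhibitor of growth, a lower number a stronger inhibitor of growth), compound 1 (`CC(=O)N1CCN(c2ccc(Nc3ncc(C(F)(F)F)c(N4Cc5cccc(N(C)S(C)(=O)=O)c5C4)n3)cc2)CC1`) gives 730 nM. In the same read-out compound 2 (`COc1cc(N2CCN(C(C)=O)CC2)ccc1Nc1ncc(C(F)(F)F)c(N2Cc3cccc(N(C)S(C)(=O)=O)c3C2)n1`) gives 1300 nM. Compound 3 (`COc1cc(Nc2ncc(C(F)(F)F)c(N3Cc4cccc(N(C)S(C)(=O)=O)c4C3)n2)c(OC)cc1Cl`) gives 16500 nM, the highest of the three numbers and beyond the scatter of both compound 1 and compound 2.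

The next entry is compound 4 (`CN(c1cccc2c1CN(c1nc(Nc3ccc(C(F)(F)F)cc3)ncc1C(F)(F)F)C2)S(C)(=O)=O`), not yet measured. The change is 4-(trifluoromethyl)phenyl in place of 4-chloro-2,5-dimethoxyphenyl on a nitrogen on an aromatic ring. In short, 4-(trifluoromethyl)phenyl stands in place of 4-chloro-2,5-dimethoxyphenyl on a nitrogen on an aromatic ring.

For the measured compounds named here, neither compound 1 nor compound 2 carries the group that leaves or the group that enters, so no measured step covers this exchange. Going by the values given here, the only measured step is a 1.8-fold higher number from compound 1 to compound 2 (0.25 log units; within the scatter), for methoxy in place of hydrogen on an aromatic carbon, and it lies within the scatter. It offers a loose guide for the methoxy groups that leave, and nothing for the chlorine or the trifluoromethyl.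

As far as these compounds go, on that evidence, no step beyond the scatter is expected in this assay, and the direction remains open. The estimated step is a 1.5-fold lower number from compound 3 to compound 4 (0.18 log units; within the scatter). For compound 4 the expected value is 11000 nM, with an estimated range of 3000 nM to 40000 nM.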

Compound 4, concentration for 50% growth inhibition: > 30000 nM
Compound 4: a limit, no number; the forecaster's own chance of this, stated with the estimate: 15%; at least 2.7-fold (0.43 log units) between middle value and limit.
By their numbers in this assay, from the lowest: compounds 1 and 2 (each within the scatter of the next); then compound 3. At a limit, above all of these: compound 4.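

Compound 4 gives a limit of this assay, not a number: the limit of > 30000 nM in this assay, at which 1 of the 4 values shown sits. Exchanging 4-chloro-2,5-dimethoxyphenyl for 4-(trifluoromethyl)phenyl on a nitrogen on an aromatic ring brings no gain in growth inhibition, and the reading is an at least 1.8-fold higher number from compound 3 to compound 4 (0.25 log units; that floor lies within the scatter); because only a floor is available, the size of this step stays undefined, and compound 4 cannot yet be firmly separated from compound 3. The comparison with the better compound in the set is clearer: trifluoromethyl in place of 4-acetylpiperazin-1-yl on an aromatic carbon gives an at least 41-fold higher number from compound 1 to compound 4 (1.61 log units; beyond the scatter), so the loss at this carbon is large, which the earlier methoxy step within the scatter gave no sign of.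

As far as these compounds go, how far compound 4 lies past its limit remains open, and so does the part played by the acetyl group of the 4-acetylpiperazin-1-yl substituent. A free piperazine, a morpholine or a short chain ending in an amine on the same aromatic carbon would show whether the activity of compound 1 depends on the whole substituent or only on a ring amine.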